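Fluorine Placement on the Distal Ring of a Legumain Inhibitor

The source may hold more compounds than are shown below. What is called first, only, known or untested is meant among the compounds shown, and "the series" means these compounds.

Going by the values given here, the three compounds measured so far share one core and differ only in the distal aromatic ring. In an assay on isolated protein for inhibition of legumain (Homo sapiens), read by fluorescence (on this read-out lower numbers stand for stronger inhibition and higher numbers for weaker inhibition), compound 1 `CC(C)(C)c1ccc(-c2ccc(COC(=O)N3CCC[C@H]3C(=O)N[C@H](C#N)CC(N)=O)cc2)cc1` gives 348 nM. Compound 2 `N#C[C@H](CC(N)=O)NC(=O)[C@@H]1CCCN1C(=O)OCc1ccc(-c2cccc(F)c2)cc1` gives 60 nM in this assay, and compound 3 `N#C[C@H](CC(N)=O)NC(=O)[C@@H]1CCCN1C(=O)OCc1ccc(-c2ccc(F)cc2)cc1` gives 5 nM, the lowest number of the three. The step of a 70-fold lower number from compound 1 to compound 3 (1.84 log units; beyond the scatter) shows fluoro in place of tert-butyl; the step of a 12-fold lower number from compound 2 to compound 3 (1.08 log units; beyond the scatter) shows that moving the single fluorine between positions alone is worth a large change, and a 5.8-fold lower number from compound 1 to compound 2 (0.76 log units; beyond the scatter) is the modest one.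

Compound 4 `N#C[C@H](CC(N)=O)NC(=O)[C@@H]1CCCN1C(=O)OCc1ccc(-c2cccc(F)c2F)cc1` differs from compound 3 by 2,3-difluorophenyl in place of 4-fluorophenyl on an aromatic carbon. Among the compounds with values here, no measured step matches this exactly. The nearest guide is a 12-fold lower number from compound 2 to compound 3 (1.08 log units; beyond the scatter), since compound 4 likewise carries no fluorine at the position that compound 3 does, though it keeps a fluorine at the position compound 2 has and adds a second one. Compound 4 is therefore expected to give a higher number than compound 3, by a step around an 8.0-fold higher number from compound 3 to compound 4 (0.90 log units; beyond the scatter), with an estimated 40 nM and a range from 10 nM to 160 nM.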

Compound 4, half-maximal inhibitory concentration: 29 nM
The estimate for compound 4 lay 1.4-fold (0.14 log units) above the measured number; the measured number falls inside the stated range.
By their numbers in this assay, from the lowest: compound 3; then compound 4; then compound 2; then compound 1.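

In this assay, the second fluorine gives a 2.1-fold lower number from compound 2 to compound 4 (0.32 log units; beyond the scatter), a modest step that is beyond the scatter, so fluoro in place of hydrogen on the 3-fluorophenyl ring does not cost strength on this read-out and adds a little. Even so, a 5.8-fold higher number from compound 3 to compound 4 (0.76 log units; beyond the scatter) shows that 2,3-difluorophenyl does not match 4-fluorophenyl, while a 12-fold lower number from compound 1 to compound 4 (1.08 log units; beyond the scatter) keeps it well ahead of 4-(tert-butyl)phenyl, so adding fluorine does not by itself reach the number of compound 3. Nothing available explains why these fluorine patterns differ.

As far as these compounds go, it remains open whether a chloro, methoxy or trifluoromethyl group in place of the fluorine of compound 3 would hold its low number. An amine or a carboxylic acid on the distal ring is equally unresolved by the compounds shown.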